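The compounds below may be only part of what the source reports. "The series", "measured", "known", "first", "only" and "open" are said of these compounds alone.

Of the compounds shown here, three built on one shared core have been tested, and a fourth waits its turn. Compound 1 `COc1ccc(/N=C\c2cn(-c3ccc(Cl)cc3)nc2-c2ccc(C)cc2)cc1`, compound 2 `Cc1ccc(-c2nn(-c3ccc(Cl)cc3)cc2/C=N\c2ccc(Cl)cc2)cc1` and compound 3 `COc1ccc(/N=C\c2cn(-c3ccc(Cl)cc3)nc2-c2ccc(OC)cc2)cc1` were each run in a functional assay on the whole organism (strain Wistar albino) for inhibition, with Rattus norvegicus as the target, read by paw edema, with stated times of 1 h and 3 h, at a dose of 0.32 mmol/kg by the intraperitoneal route; a higher number here means more inhibition at the dose given (going by the name of the read-out), a lower number less inhibition. In this assay compound 1 gives 48.9%, compound 2 gives 49.2% and compound 3 gives 82.2%. Compound 2 differs from compound 1 by chloro in place of methoxy on an aromatic carbon, and that exchange produced a number 0.3 percentage points higher from compound 1 to compound 2 (within the scatter). Compound 3 differs from compound 1 in its core by methoxy in place of methyl on an aromatic carbon, which produced a number 33.3 percentage points higher from compound 1 to compound 3 (beyond the scatter), so compound 3 stands highest of the three numbers.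

Compound 4 `COc1ccc(-c2nn(-c3ccc(Cl)cc3)cc2/C=N\c2ccc(Cl)cc2)cc1` has not yet been measured. It differs from compound 3 by chloro in place of methoxy on an aromatic carbon, the same change as from compound 1 to compound 2, now carried out on the core of compound 3. Because the step from compound 1 to compound 2 was a number 0.3 percentage points higher from compound 1 to compound 2 (within the scatter), a similarly small step is expected here, a number 2.2 percentage points lower from compound 3 to compound 4 (within the scatter). Compound 4 is therefore estimated to give 80% in this assay, most likely between 65% and 92%.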

Compound 4, a percentage reported as inhibition, in the whole organism at one dose (the size of the read-out at that dose, not a potency): 72.6%
The estimate for compound 4 lay 7.4 percentage points above the measured number; the range from low to high includes it.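

In this assay, exchanging 4-methoxyphenyl for 4-chlorophenyl gave a number 9.6 percentage points lower from compound 3 to compound 4 (within the scatter), so the change did about as little here as it did on the first core: the same change on two cores in this assay, a number 0.3 percentage points higher (within the scatter) from compound 1 to compound 2 and a number 9.6 percentage points lower (within the scatter) from compound 3 to compound 4, 9.9 percentage points apart, within the scatter of two such steps

The other exchange, methoxy in place of methyl, also carried over from one core to the other, with a number 23.4 percentage points higher from compound 2 to compound 4 (beyond the scatter): the same change on two cores in this assay, a number 33.3 percentage points higher (beyond the scatter) from compound 1 to compound 3 and a number 23.4 percentage points higher (beyond the scatter) from compound 2 to compound 4, 9.9 percentage points apart, within the scatter of two such steps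

Within these four compounds, then, each change behaves alike on both cores, but two cores per change are a thin basis, and this says nothing about why the numbers move or whether the same would hold on a further core.

The compounds shown leave open what other groups would do on this aromatic carbon, for instance a fluoro, an amine or a carboxylic acid, or a longer chain such as butoxy in place of methoxy. They also leave open whether the same picture would appear at other doses, since each number comes from a single dose.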